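This account rests on a few compounds, and the source may have more. Where it says the series, first, only, none or still open, it means among the compounds named here.

Measured in an assay on cells with melanin-concentrating hormone receptor 1 (Homo sapiens) as the target, read by radioligand binding; on this read-out higher numbers stand for weaker inhibition and lower numbers for stronger inhibition:
- compound 1 `CCOCCOc1cccc2ccc(N)nc12`: > 2000 nM
- compound 2 `CCCCOc1cccc2ccc(N)nc12`: 789 nM
- compound 3 `CCCC(C)Oc1cccc2ccc(N)nc12`: 105 nM

The value of compound 1 is a limit of the assay and not a number (the limit of > 2000 nM in this assay, at which 1 of the 3 values shown sits). Against compound 2 the change is ethoxy in place of ethyl on a saturated chain carbon, two bonds along the chain from an oxygen on an aromatic ring, and in this assay it gives an at least 2.5-fold higher number from compound 2 to compound 1 (0.40 log units; beyond the scatter). Compound 3 differs from compound 2 by methyl in place of hydrogen on a saturated chain carbon bound to an oxygen on an aromatic ring and a saturated chain carbon, with a 7.5-fold lower number from compound 2 to compound 3 (0.88 log units; beyond the scatter).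

Compound 4 `CCOCC(C)Oc1cccc2ccc(N)nc12` is not yet measured. It stands to compound 3 as compound 1 stands to compound 2: ethoxy in place of ethyl on a saturated chain carbon, two bonds along the chain from an oxygen on an aromatic ring. The place of the change is the same in both pairs; only the core differs, as told by methyl in place of hydrogen on a saturated chain carbon bound to an oxygen on an aromatic ring and a saturated chain carbon. Since the earlier step was an at least 2.5-fold higher number from compound 2 to compound 1 (0.40 log units; beyond the scatter), a step of about a 3.8-fold higher number from compound 3 to compound 4 (0.58 log units; beyond the scatter) is expected from compound 3 to compound 4, resting on that one measured pair. For compound 4 in this assay the estimate is 400 nM, between 150 nM and 1500 nM.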

Compound 4, half-maximal inhibitory concentration: 1070 nM
Compound 4: the middle estimate sits 2.7-fold (0.43 log units) below what was measured; the measured number falls inside the stated range.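

In this assay, ethoxy in place of ethyl gives a 10-fold higher number from compound 3 to compound 4 (1.01 log units; beyond the scatter), the same direction as an at least 2.5-fold higher number from compound 2 to compound 1 (0.40 log units; beyond the scatter), so the direction of this change carries across these two cores. Compound 1 stands at a limit of the assay, > 2000 nM, so a carry-over of the size of the step is not shown: the same change on two cores in this assay, an at least 2.5-fold higher number (0.40 log units; beyond the scatter) from compound 2 to compound 1 and a 10-fold higher number (1.01 log units; beyond the scatter) from compound 3 to compound 4; the limit leaves it open whether they differ The methyl change gives no clearer reading, since a 1.4-fold higher number from compound 2 to compound 4 (0.13 log units; within the scatter) differs in more than one place and an at least 1.8-fold lower number from compound 1 to compound 4 (0.27 log units; that floor lies within the scatter) is only a floor: the same change on two cores in this assay, a 7.5-fold lower number (0.88 log units; beyond the scatter) from compound 2 to compound 3 and an at least 1.8-fold lower number (0.27 log units; that floor lies within the scatter) from compound 1 to compound 4; the limit leaves it open whether they differ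

The evidence rests on two cores and a single pair of groups. From the compounds shown here alone, whether an amine or a longer chain in place of ethoxy at this place follows the same direction remains open.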